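A few compounds are considered here, and "the series" means these few. Any claim that something is new, unique, unknown or untested is made for them only; others in the source may bear on it.

Measured in a functional assay on HCC827 cells (Homo sapiens) for antiproliferative activity, read by MTT assay, with a stated time of 72 h; a higher number here means a weaker inhibitor, a lower number a stronger inhibitor:
compound 1 `CN1CCN(c2ccc(Nc3ncc4nc(Nc5ccc(F)cc5)n([C@H]5CCN(C(=O)CO)C5)c4n3)cc2)CC1` gives 380 nM
compound 2 `CN1CCN(c2ccc(Nc3ncc4nc(Nc5ccccc5)n([C@H]5CCN(S(=O)(=O)C6CC6)C5)c4n3)cc2)CC1` gives 1.6 nM

Compound 1 holds the higher of the two numbers in this assay; compound 2, which differs from it in more than one place, gives the lower number, and that gap lies beyond the scatter. For the measured compounds named here, no step between measured compounds that differ in a single place is available, so nothing here isolates what a change of the group on the aromatic nitrogen does on its own.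

Compound 3 `CN1CCN(c2ccc(Nc3ncc4nc(Nc5ccc(F)cc5)n([C@H]5CCCN(C(=O)CO)C5)c4n3)cc2)CC1` is not yet measured. It differs from compound 1 in one place: 1-((hydroxymethyl)carbonyl)piperidin-3-yl in place of 1-((hydroxymethyl)carbonyl)pyrrolidin-3-yl on an aromatic nitrogen. Going by the values given here, with no measured step of this kind to lean on, the expected step is a 1.1-fold higher number from compound 1 to compound 3 (0.04 log units; within the scatter), small and within the scatter, with no firm direction. Compound 3 is accordingly estimated at 420 nM in this assay, with a range from 130 nM to 1400 nM.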

Compound 3, half-maximal inhibitory concentration: 1.8 nM
Beside the measured number, compound 3's estimate is 230-fold (2.37 log units) above it; measured number outside the range, below it.
By their numbers in this assay, from the lowest: compounds 2 and 3 (each within the scatter of the next); then compound 1.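

For the compounds shown here, on the aromatic nitrogen, with the (4-fluorophenyl)amino group unchanged, this is the first single-place step, and it shows that the position is highly sensitive to the ring carrying the (hydroxymethyl)carbonyl group: in this assay, 1-((hydroxymethyl)carbonyl)piperidin-3-yl in place of 1-((hydroxymethyl)carbonyl)pyrrolidin-3-yl gives a 210-fold lower number from compound 1 to compound 3 (2.32 log units; beyond the scatter). The two groups have the same counts of hydrogen-bond donors and acceptors, so the large step goes with the six-membered ring in place of the five-membered ring, not with any difference in those counts. Nothing available explains the size of this step.

As far as these compounds go, it remains open whether the step holds for the opposite configuration at the defined stereocentre. From the compounds shown here alone, it is also open whether it carries over when an acryloyl or acetyl group stands on the ring nitrogen, or whether a seven-membered ring extends it.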